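The compounds below may be only part of what the source reports. "The series", "measured", "known", "first", "only" and "open" are said of these compounds alone.

In a functional assay on HepG2 cells (Homo sapiens) for cytotoxicity, read by MTT assay, with a stated time of 48 h (a higher number here means a weaker inhibitor, a lower number a stronger inhibitor), compound 2 `CCCCCCCCOc1ccc2c(Cl)ccnc2c1` gives 2640 nM, the larger of the two numbers shown, though it lies within the scatter of the value of compound 1 `CC(C)COc1ccc2c(Cl)ccnc2c1`, which in this assay gives 2250 nM. Compound 3 `CCCCCCOc1ccc2c(Cl)ccnc2c1` differs from compound 2 by hydrogen in place of ethyl on a saturated chain carbon, six bonds along the chain from an oxygen on an aromatic ring. Among the compounds with values here, no step between measured compounds covers this change, but compound 1 at 2250 nM and compound 2 at 2640 nM sit within the scatter of each other despite their different chains, so a 1.1-fold lower number from compound 2 to compound 3 (0.04 log units; within the scatter) is expected in this assay to stay within the scatter. Compound 3 is estimated at 2400 nM, in a range from 1200 nM to 4800 nM.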

Compound 3, half-maximal inhibitory concentration: 2420 nM
For compound 3 the middle estimate is 1.0-fold (0.00 log units) below the measured one; the range from low to high includes it.
By their numbers in this assay, from the lowest: compounds 1, 3 and 2 (each within the scatter of the next).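

Hydrogen in place of ethyl on this saturated chain carbon gives a 1.1-fold lower number from compound 2 to compound 3 (0.04 log units; within the scatter) in this assay, and pentyl in place of isopropyl gives a 1.1-fold higher number from compound 1 to compound 3 (0.03 log units; within the scatter) for the chain on the same oxygen. Neither change separates the compounds in this assay, so these chain changes now stand as direct steps that leave the read-out within the scatter. Nothing measured here speaks to why these chains read alike. On these data alone, whether an amine or a carboxylic acid on this chain carbon would move the number beyond the scatter stays open.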